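Aryl swap on the piperazine nitrogen: fluoro replacing methoxy

The source may report more compounds than this note shows. Statements on the series, on what has been measured and on what is new or still open speak of the compounds shown alone.

Three compounds share one core and differ only in the aryl group on the amine nitrogen in the ring. Compound 1 `CCCc1nc(-c2ccccc2)c(CNCCN2CCN(c3cccc(C(F)(F)F)c3)CC2)o1` gives 1940 nM in an assay on HEK293 cells for inhibition of Voltage-dependent T-type calcium channel subunit alpha-1G (Homo sapiens), read by patch clamp; on this read-out higher numbers stand for weaker inhibition and lower numbers for stronger inhibition. Compound 2 `CCCc1nc(-c2ccccc2)c(CNCCN2CCN(c3ccccc3C)CC2)o1` gives 4300 nM, and compound 3 `CCCc1nc(-c2ccccc2)c(CNCCN2CCN(c3ccc(OC)cc3)CC2)o1` gives 9200 nM. Compound 3 thus stands highest of the three numbers, with the steps of a 4.7-fold higher number from compound 1 to compound 3 (0.68 log units; beyond the scatter) and a 2.1-fold higher number from compound 2 to compound 3 (0.33 log units; beyond the scatter) both beyond the scatter; the step of a 2.2-fold higher number from compound 1 to compound 2 (0.35 log units; beyond the scatter) is likewise modest but beyond the scatter.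

Compound 4 `CCCc1nc(-c2ccccc2)c(CNCCN2CCN(c3ccc(F)cc3)CC2)o1` follows from compound 3 by fluoro in place of methoxy on an aromatic carbon. Among the compounds with values here, no measured step repeats this exact change; the three steps bear on it only in that every aryl change here moved the number by a modest amount, and the smaller substituents did not give the lowest number, which belongs to compound 1 with trifluoromethyl. Replacing methoxy by fluoro on an aromatic carbon of a six-membered aromatic ring of carbon only is expected to give compound 4 a modestly lower number, a 2.0-fold lower number from compound 3 to compound 4 (0.31 log units; beyond the scatter), with a step of about the size seen between compound 2 and compound 3 and plainly not beyond what the series shows. The estimate for compound 4 in this assay is 4500 nM, with a range from 1800 nM to 11000 nM.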

Compound 4, half-maximal inhibitory concentration: 7080 nM
For compound 4 the middle estimate is 1.6-fold (0.20 log units) below the measured one; measured number inside the range.
By their numbers in this assay, from the lowest: compound 1; then compounds 2, 4 and 3 (each within the scatter of the next, the first and the last beyond it).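

Fluoro in place of methoxy, para to a large group, stays within the scatter in this assay: a 1.3-fold lower number from compound 3 to compound 4 (0.11 log units; within the scatter), so at this position the two groups cannot be told apart, even though fluoro brings one heavy atom rather than two and no hydrogen-bond acceptor. Within the data shown here, compound 4 also cannot be told apart from the 2-methylphenyl analogue, a 1.6-fold higher number from compound 2 to compound 4 (0.22 log units; within the scatter), although compounds 2 and 3 are separated beyond the scatter, so the small gap between those two no longer reads as a clear ladder among the aryl groups, while 3-(trifluoromethyl)phenyl remains the only aryl group set apart from all the others, a 3.6-fold higher number from compound 1 to compound 4 (0.56 log units; beyond the scatter). Nothing available on these compounds accounts for why the change at this position moves the number so little.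

Open, as far as these compounds go, is whether trifluoromethyl para to a large group would give a number like that of compound 1, which would show whether the group or its place matters, and how a nitrile, a hydroxyl or a carboxylic acid would read in that same place. Also open, from the compounds shown here alone, is whether these aryl steps would hold with a longer chain on the shared core.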